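The source may hold more compounds than are shown below. What is called first, only, known or untested is meant among the compounds shown, and "the series" means these compounds.

Measured compounds:
- compound 1 `COc1ncc(-c2ccc3nc(NC(=O)NCCN4CCCC4)sc3c2)cc1NS(=O)(=O)c1ccc(F)cc1`: 300 nM in a functional assay on A549 cells (Homo sapiens) for antiproliferative activity, read by MTT assay, with a stated time of 72 h; on this read-out higher numbers stand for weaker inhibition and lower numbers for stronger inhibition
- compound 2 `CNC(=O)Nc1nc2ccc(-c3cnc(OC)c(NS(=O)(=O)c4ccc(F)cc4)c3)cc2s1`: 1560 nM in this assay
- compound 3 `COc1ncc(-c2ccc3nc(NC(=O)NCCN4CCCCC4)sc3c2)cc1NS(=O)(=O)c1ccc(F)cc1`: 330 nM in this assay

Compound 3 holds the second highest of the three numbers. Its nearest neighbour is compound 1, with a 1.1-fold higher number from compound 1 to compound 3 (0.04 log units; within the scatter); its furthest is compound 2, with a 4.7-fold lower number from compound 2 to compound 3 (0.67 log units; beyond the scatter).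

Compound 4 `COc1ncc(-c2ccc3nc(NC(=O)NCCN4CCN(C)CC4)sc3c2)cc1NS(=O)(=O)c1ccc(F)cc1` is not yet measured. Its change from compound 3: 4-methylpiperazin-1-yl in place of piperidin-1-yl on a saturated chain carbon, two bonds along the chain from an amide-type nitrogen.

Among the compounds with values here, two measured steps bear on this. The step from compound 2 to compound 3 shows that adding a ring amine at the end of the chain matters, with a 4.7-fold lower number from compound 2 to compound 3 (0.67 log units; beyond the scatter). The step from compound 1 to compound 3, which swaps one saturated ring for another at the same place, gives a 1.1-fold higher number from compound 1 to compound 3 (0.04 log units; within the scatter). The change to compound 4 again exchanges one such ring for another at that place, so no step beyond the scatter is expected in this assay from compound 3 to compound 4.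

Compound 4 is therefore estimated at 330 nM, range 150 nM to 750 nM, a step of no change at the digits printed from compound 3 to compound 4 (within the scatter) expected.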

Compound 4, half-maximal inhibitory concentration: 550 nM
Beside the measured number, compound 4's estimate is 1.7-fold (0.22 log units) below it; the range from low to high includes it.
By their numbers in this assay, from the lowest: compounds 1, 3 and 4 (each within the scatter of the next); then compound 2.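

In this assay, 4-methylpiperazin-1-yl at this place on the chain reads like the two rings with a single ring nitrogen: a 1.7-fold higher number from compound 3 to compound 4 (0.22 log units; within the scatter) and a 1.8-fold higher number from compound 1 to compound 4 (0.26 log units; within the scatter) are both printed within the scatter, so the position has now accepted three saturated rings, one of them with a second ring nitrogen and a methyl on it, without a step that can be told from noise. The advantage of a ring amine on the chain over the hydrogen of compound 2 also holds for this third ring, with a 2.8-fold lower number from compound 2 to compound 4 (0.45 log units; beyond the scatter) as a step beyond the scatter. No measurement here bears on why these rings read alike.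

From the compounds shown here alone, whether morpholin-4-yl, an open-chain dimethylamino group or a longer chain carrying the same rings would stay at this level remains open. Whether these rings also read alike outside this assay is open as well.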